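A few compounds are considered here, and "the series" means these few. Any claim that something is new, unique, unknown or untested is made for them only; others in the source may bear on it.

In a functional assay on CHO cells for positive allosteric modulation of muscarinic acetylcholine receptor M5 (Homo sapiens), read by calcium flux (a lower number here means a smaller maximal response, a higher number a larger maximal response), the measured compounds stand as follows:

compound 1 `CCN(C(=O)C1CCN(S(=O)(=O)c2ccc(OC)cc2)CC1)[C@@H](C)c1ccccc1`: "not determined" (no result reported)
compound 2 `CC(C)N(Cc1ccccc1C(F)(F)F)C(=O)C1CCN(S(=O)(=O)c2ccc3[nH]ncc3c2)CC1`: 54%
compound 3 `O=C(C1CCN(S(=O)(=O)c2ccc3[nH]ncc3c2)CC1)N(Cc1ccccc1C(F)(F)F)C1CC1`: "not determined" (no result reported)

Compound 3 thus has no single number in this assay; only compound 2, which shares the same core, gives a value there. Compound 4 `CC(C)(C)CN(Cc1ccccc1C(F)(F)F)C(=O)C1CCN(S(=O)(=O)c2ccc3[nH]ncc3c2)CC1` differs from compound 3 in one place: neopentyl in place of cyclopropyl on an amide-type nitrogen. Among the measured compounds shown here, with no number for compound 3, no step to compound 4 can be measured, and the size of any change in this assay cannot be foreseen from these compounds beyond saying that a value near that of compound 2 seems plausible. Compound 4 is therefore expected to reach about 55% in this assay, within a range of 35% to 75%.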

Compound 4, largest response reached (reported as percent of maximum), in percent of the reference or control that the assay uses: 104%
Estimate against measurement, compound 4: 49 percentage points below, and the stated range ends below it.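

In this assay, the group on the amide-type nitrogen turns out to have a strong hold on the maximal response: neopentyl in place of isopropyl gives a number 50 percentage points higher from compound 2 to compound 4 (beyond the scatter). Among the compounds shown here, the earlier compounds offered only one value at this position, so they could not show this, and the step from cyclopropyl in compound 3 to neopentyl in compound 4 cannot be read. Nothing at hand explains the rise. The compounds shown leave open whether a longer chain such as n-hexyl, or a cyclohexyl ring, on this nitrogen would keep the response of compound 4.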